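The source may report more compounds than this note shows. Statements on the series, on what has been measured and on what is new or still open speak of the compounds shown alone.

Three compounds share one core and differ only in the outer groups attached to it. Compound 1 `O=C(Nc1cccc(-n2cc(-c3ccncc3)c(-c3cc(O)cc(Cl)c3)n2)c1)Nc1ccc(Cl)c(C(F)(F)F)c1` and compound 2 `O=C(Nc1cccc(-n2cc(-c3ccncc3)c(-c3cc(O)cc(Cl)c3)n2)c1)Nc1ccc(Cl)c(Cl)c1` carry different groups on the far aromatic ring of the urea, and compound 3 `COc1cc(Cl)cc(-c2nn(-c3cccc(NC(=O)Nc4ccc(Cl)c(Cl)c4)c3)cc2-c2ccncc2)c1` differs from compound 2 only at the oxygen on the chloro-bearing ring. In a functional assay on CCRF-CEM cells (Homo sapiens) for inhibition, read by sulforhodamine B assay, with a stated time of 48 h, tested at 0.1 uM (on this read-out lower numbers stand for a stronger effect and higher numbers for a weaker effect at the one concentration tested), compound 1 gives 95%, compound 2 gives 95% and compound 3 gives 97%. The two measured steps, no change at the digits printed from compound 1 to compound 2 (within the scatter) and a number 2 percentage points higher from compound 2 to compound 3 (within the scatter), are both small, so compound 3 sits among numbers that cannot be told apart, and all three show only a weak effect at this concentration.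

Compound 4 `COc1cc(Cl)cc(-c2nn(-c3cccc(NC(=O)c4cccc(C(F)(F)F)c4)c3)cc2-c2ccncc2)c1` is the next step from compound 3: 3-(trifluoromethyl)phenyl in place of (3,4-dichlorophenyl)amino on a carbonyl carbon. Neither measured step touches this part of the molecule, so none bears directly on it; they show only that the surroundings tolerate small changes without moving the read-out. With a weak starting point and no contrary sign, the step of a number 2 percentage points lower from compound 3 to compound 4 (within the scatter) is expected to stay within the scatter. The estimate for compound 4 in this assay is therefore 95%, within 82% to 105%.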

Compound 4, a percentage reported as activity, at one concentration (the size of the read-out at that concentration, not a potency): 92%
Compound 4: middle estimate off by 3 percentage points, on the high side, within the range that was stated.
By their numbers in this assay, from the lowest: compounds 4, 1, 2 and 3 (each within the scatter of the next).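

In this assay, replacing (3,4-dichlorophenyl)amino with 3-(trifluoromethyl)phenyl on the carbonyl carbon gives a number 5 percentage points lower from compound 3 to compound 4 (within the scatter). The earlier steps altered only small groups, whereas this one exchanges the whole outer ring unit, turns the urea into an amide and removes a hydrogen-bond donor, yet the read-out stays within the scatter, so neither the urea nitrogen nor the chlorine pattern is shown to matter here. No measurement available here accounts for this flat result.

With every compound showing only a weak effect at the one concentration tested, a real difference between them could remain hidden, so these numbers cannot rank them. Also open, as far as these compounds go, is how the read-out would respond if the far ring carried an amine or a carboxylic acid, or if a longer chain replaced that ring.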